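The compounds below may be only part of what the source reports. "The series", "measured", "known", "first", "only" and "open" are said of these compounds alone.

Measured so far:
compound 1 `COC(=O)C1=C(C)NC(=S)NC1c1ccsc1` — 38%
compound 2 `CCCOC(=O)C1=C(C)NC(=S)NC1c1ccsc1` — 26%
compound 3 `COC(=O)C1=C(C)N(C)C(=O)NC1c1ccco1` — 31%

In an assay on membranes from HEK293 cells for displacement of a labelled ligand from adenosine receptor A2b (Homo sapiens), read by scintillation counting, with a stated time of 30 min, tested at 1 uM (a lower number here means less inhibition, a higher number more inhibition at the concentration tested (going by the name of the read-out)), compound 1 gives 38% and compound 2 gives 26%; the change between them is ethyl in place of hydrogen on a saturated chain carbon bound to an oxygen next to a carbonyl group, and the step it made is a number 12 percentage points lower from compound 1 to compound 2 (beyond the scatter). Compound 3 sits on a different core; how the two cores differ is not broken down here. In this assay compound 3 gives 31%, which lies within the scatter of both compound 1 and compound 2.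

Compound 4 `CCCOC(=O)C1=C(C)N(C)C(=O)NC1c1ccco1` carries the same change on the core of compound 3, namely (ethyl in place of hydrogen on a saturated chain carbon bound to an oxygen next to a carbonyl group). Going by the values given here, the step expected from compound 3 to compound 4 in this assay is a number 10 percentage points lower from compound 3 to compound 4 (within the scatter), resting on the single earlier instance a number 12 percentage points lower from compound 1 to compound 2 (beyond the scatter), seen once only and on another core. The value expected for compound 4 is 21%, with a range from 8% to 34%.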

Compound 4, a percentage reported as inhibition, at one concentration (the size of the read-out at that concentration, not a potency): 23%
Compound 4: the middle estimate sits 2 percentage points below what was measured; measured number inside the range.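

In this assay, the change from methoxycarbonyl to propoxycarbonyl gives a number 8 percentage points lower from compound 3 to compound 4 (within the scatter). Set beside the earlier step, the two agree: the same change on two cores in this assay, a number 12 percentage points lower (beyond the scatter) from compound 1 to compound 2 and a number 8 percentage points lower (within the scatter) from compound 3 to compound 4, 4 percentage points apart, within the scatter of two such steps

The step on the core of compound 1 thus fits what the core of compound 3 gives, but the second step alone cannot be told from scatter, and two cores give no rule for any further core. Open, going by these compounds, is how a longer chain such as butoxycarbonyl, or a carboxylic acid or an amide in place of the ester, would read on either core. A read-out at one concentration also leaves the potency of all these compounds open.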